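A few compounds are considered here, and "the series" means these few. Any claim that something is new, unique, unknown or untested is made for them only; others in the source may bear on it.

Measured so far:
compound 1, `Cc1cn(C)nc1Nc1cc2c(c(N)n1)c(C#N)c(N1CCC[C@H]1C)n2C`: 2110 nM
compound 2, `C[C@@H]1CCCN1c1c(C#N)c2c(N)nc(Nc3cn(C)nc3Cl)nc2n1C`: 34 nM

In an assay on isolated protein for inhibition of Leucine-rich repeat serine/threonine-protein kinase 2 (Homo sapiens), read by TR-FRET and LanthaScreen, with stated times of 50 min and 30 min, in the presence of a further agent that is not named here (a higher number here means a weaker inhibitor, a lower number a stronger inhibitor), compound 2 gives 34 nM, the lowest of the two numbers on hand. In this assay compound 1 gives 2110 nM, a markedly higher number; these two compounds differ in more than one place, so only the two values themselves can be compared.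

Compound 3, `Cc1nn(C)cc1Nc1nc(N)c2c(C#N)c(N3CCC[C@H]3C)n(C)c2n1`, has not been measured. It differs from compound 2 by methyl in place of chloro on an aromatic carbon. Among the measured compounds shown here, no measured pair isolates this change, so the size of the step is uncertain. A small shift toward a higher number is expected, as the step of a 2.4-fold higher number from compound 2 to compound 3 (0.37 log units; beyond the scatter), but a result within the scatter of compound 2 would not be surprising. Compound 3 is therefore estimated at 80 nM in this assay, with a range of 25 nM to 300 nM.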

Compound 3, half-maximal inhibitory concentration: 38 nM
Beside the measured number, compound 3's estimate is 2.1-fold (0.32 log units) above it; the measured number falls inside the stated range.
By their numbers in this assay, from the lowest: compounds 2 and 3 (each within the scatter of the next); then compound 1.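

Among the compounds shown here, the step from 3-chloro-1-methyl-1H-pyrazol-4-yl to 1,3-dimethyl-1H-pyrazol-4-yl in this assay is the first change that can be read at a single place (a 1.1-fold higher number from compound 2 to compound 3 (0.05 log units; within the scatter)). At this aromatic carbon, therefore, chloro and methyl cannot be told apart in this assay, which the earlier pair, differing in more than one place, could not show. Nothing measured here offers an explanation for this result.

Going by these compounds, whether this position accepts other groups, such as hydrogen, ethyl, methoxy or an amine, remains open, as the two groups compared here each have a single heavy atom. Also open is which structural difference accounts for the higher number of compound 1 (2110 nM), as no single-place step connects it to the other compounds.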